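Indazole sulfonamide piperidine amides as M5 positive modulators

This account rests on a few compounds, and the source may have more. Where it says the series, first, only, none or still open, it means among the compounds named here.

The measured compounds and their values:
- compound 1, `CCN(Cc1ccccc1)C(=O)C1CCN(S(=O)(=O)c2ccc(OC)c(OC)c2)CC1`, 57%
- compound 2, `CCN(Cc1ccccc1)C(=O)C1CCN(S(=O)(=O)c2cccnc2)CC1`, "not determined" (no result reported)
- compound 3, `CCN(Cc1cccc(F)c1)C(=O)C1CCN(S(=O)(=O)c2ccc3cn[nH]c3c2)CC1`, 89%

In a functional assay on CHO cells for positive allosteric modulation of muscarinic acetylcholine receptor M5 (Homo sapiens), read by calcium flux (on this read-out higher numbers stand for larger maximal responses and lower numbers for smaller maximal responses), compound 3 gives the highest of the two numbers that were obtained. Its nearest neighbour on the numbers is compound 1, which in this assay gives 57%, a value that lies beyond the scatter below that of compound 3. Compound 2 was run in this assay but gave "not determined" (no result reported), so no number stands for it.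

Compound 4, `CCN(Cc1ccccc1C)C(=O)C1CCN(S(=O)(=O)c2ccc3cn[nH]c3c2)CC1`, has not yet been measured. It differs from compound 3 in one place: 2-methylphenyl in place of 3-fluorophenyl on a saturated chain carbon bound to an amide-type nitrogen. Going by the values given here, no step between two measured compounds covers this change, so the expected size of the step rests only on compound 3 and its standing.

The account expects a small downward step from compound 3 to compound 4, a number 14 percentage points lower from compound 3 to compound 4 (beyond the scatter), in this assay, not clearly beyond the scatter. For compound 4 the estimate in this assay is 75%, with a range from 50% to 100%.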

Compound 4, largest response reached (reported as percent of maximum), in percent of the reference or control that the assay uses: 103%
The estimate for compound 4 lay 28 percentage points below the measured number; measured number above the stated range.
By their numbers in this assay, from the lowest: compound 1; then compound 3; then compound 4.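

In this assay, the place on a saturated chain carbon bound to an amide-type nitrogen proves open to change, since 2-methylphenyl in place of 3-fluorophenyl gives a number 14 percentage points higher from compound 3 to compound 4 (beyond the scatter). The earlier compounds shown here offered no step at this place, and this one shows that the fluorine of compound 3 is not needed for a large maximal response when the shared core is kept. The swap changes both the substituent and where it is named on the ring, and nothing measured here accounts for the step.

The compounds shown leave open whether the methyl or its ring position matters more, a question that 3-methylphenyl or 2-fluorophenyl would address. They also leave open how an unsubstituted phenyl or a pyridine ring would fare at this place.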